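Notes on an aryl ether exchange and cell tolerability

The source may hold more compounds than are shown below. What is called first, only, known or untested is meant among the compounds shown, and "the series" means these compounds.

Compound 1 `COc1cccc(OC(c2ccc(C(F)(F)F)cc2)C2CCN(C(C)CCNC(=O)c3c(Cl)cncc3Cl)CC2)n1` and compound 2 `CCO/N=C(/c1ccc(Br)cc1)C1CCN(C(C)CCNC(=O)c2c(Cl)cncc2Cl)CC1` have been run in an ADME assay on PBMC cells (Homo sapiens) for cytotoxicity; a higher number here means that more compound is tolerated, a lower number that less compound is tolerated. Compound 1 gives 32700 nM, and compound 2 gives 33800 nM; the two values lie within the scatter of each other, so no order is read between them. Compound 3 `Cc1cccnc1OC(c1ccc(C(F)(F)F)cc1)C1CCN(C(C)CCNC(=O)c2c(Cl)cncc2Cl)CC1` differs from compound 1 in one place: 3-methylpyridin-2-yl in place of 6-methoxypyridin-2-yl on an oxygen on a saturated carbon. Within the data shown here, no measured pair shows a step of this kind, so nothing here sets its size. The expected step is a 1.1-fold lower number from compound 1 to compound 3 (0.04 log units; within the scatter), not beyond the scatter. Compound 3 is therefore estimated at 30000 nM, within the range 15000 nM to 60000 nM.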

Compound 3, half-maximal cytotoxic concentration: 33000 nM
For compound 3 the middle estimate is 1.1-fold (0.04 log units) below the measured one, and the stated range covers the measured number.
By their numbers in this assay, from the lowest: compounds 1, 3 and 2 (each within the scatter of the next).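

Read in this assay the exchange of 6-methoxypyridin-2-yl for 3-methylpyridin-2-yl on this oxygen is the first step available at this position (a 1.0-fold higher number from compound 1 to compound 3 (0.00 log units; within the scatter)). The entering group has 7 heavy atoms and 1 hydrogen-bond acceptor against 8 and 2 for the group that leaves, and that difference does not separate the two compounds here.

As far as these compounds go, whether an amine or a carboxylic acid on this oxygen would give a step beyond the scatter stays open. No measurement shown bears on the reason for this result.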